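An unmoved series meets a 3-chlorophenyl group

The compounds below may be only part of what the source reports. "The series", "measured", "known", "first", "only" and "open" are said of these compounds alone.

Compound 1 `Fc1ccc(-c2ccc(-c3ccc(-c4nc5ccccc5[nH]4)cc3)cc2)cc1` gives 100000 nM
Compound 2 `Oc1ccc(-c2ccc(-c3ccc(-c4nc5ccccc5[nH]4)cc3)cc2)cc1` gives 100000 nM
Compound 3 `CN(C)c1ccc(-c2ccc(-c3ccc(-c4nc5ccccc5[nH]4)cc3)cc2)cc1` gives 100000 nM

In a functional assay on Gurav cells (Homo sapiens) for inhibition, read by sulforhodamine B assay (a lower number here means a stronger inhibitor of growth, a higher number a weaker inhibitor of growth), compound 3 gives 100000 nM and so stands level with compound 1 and compound 2. Compound 4 `Clc1cccc(-c2ccc(-c3ccc(-c4nc5ccccc5[nH]4)cc3)cc2)c1` is not yet measured. It carries 3-chlorophenyl in place of 4-(dimethylamino)phenyl on an aromatic carbon. Among the compounds with values here, three measured steps bear on this swap: no change at the digits printed from compound 1 to compound 2 (within the scatter) and no change at the digits printed from compound 1 to compound 3 (within the scatter) and no change at the digits printed from compound 2 to compound 3 (within the scatter) all lie within the scatter. None of them involves chlorine, so the support is only indirect. The estimated move in this assay is no change at the digits printed from compound 3 to compound 4 (within the scatter) and no step beyond the scatter is expected in either direction. Compound 4 is estimated at 100000 nM (expected range 40000 nM to 200000 nM).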

Compound 4, concentration for 50% growth inhibition: 2190 nM
Compound 4: the middle estimate sits 46-fold (1.66 log units) above what was measured; measured number below the stated range.
By their numbers in this assay, from the lowest: compound 4; then compounds 1, 2 and 3 (each within the scatter of the next).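

In this assay the 3-chlorophenyl group gives a 46-fold lower number from compound 3 to compound 4 (1.66 log units; beyond the scatter) and a 46-fold lower number from compound 2 to compound 4 (1.66 log units; beyond the scatter) and a 46-fold lower number from compound 1 to compound 4 (1.66 log units; beyond the scatter) as well, so this position can shift growth inhibition even though the fluoro, hydroxy and dimethylamino compounds stood level. No measurement available here explains the step.

The compounds shown cannot separate the effect of the chlorine from that of its place on the ring, since compound 4 changes both at once. As far as these compounds go, what a bromine or a methoxy group would do at that place also stays open.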